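The source may report more compounds than this note shows. Statements on the series, on what has been measured and on what is new or still open speak of the compounds shown alone.

Compound 1 `CC/C(=C\c1cc(OC)c(OC)c(OC)c1)C(=O)N1CCC=C(Cl)C1=O` is the reference point of the pair measured so far: in an ADME assay on WI-38 cells (Homo sapiens) for cytotoxicity, read by MTT assay, with a stated time of 72 h (on this read-out higher numbers stand for weaker inhibition and lower numbers for stronger inhibition), compound 1 gives 5480 nM. Compound 2 `CC/C(=C\c1cc(OC)c(OC)c(OC)c1)C(=O)N1CCC=C(Br)C1=O` gives 7940 nM in this assay, and a 1.4-fold higher number from compound 1 to compound 2 (0.16 log units; within the scatter), so the two numbers are not separable and neither compound stands apart. Compound 3 `CCC/C(=C\c1cc(OC)c(OC)c(OC)c1)C(=O)N1CCC=C(Cl)C1=O` carries methyl in place of hydrogen on a saturated chain carbon, two bonds along the chain from a double-bonded chain carbon. Among the measured compounds shown here, no measured step touches this part of the chain; the only step known changes the halogen on the ring. With nothing to argue for a shift beyond the scatter, compound 3 is expected near compound 1, at 5500 nM with a range of 2500 nM to 12000 nM, which as a step means a 1.0-fold higher number from compound 1 to compound 3 (0.00 log units; within the scatter) is expected.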

Compound 3, half-maximal inhibitory concentration: 10400 nM
Compound 3: middle estimate off by 1.9-fold (0.28 log units), on the low side; measured number inside the range.
By their numbers in this assay, from the lowest: compounds 1, 2 and 3 (each within the scatter of the next).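

In this assay the change from ethyl to propyl gives a 1.9-fold higher number from compound 1 to compound 3 (0.28 log units; within the scatter) and so stays within the scatter. Among the compounds shown here, this is the first reading on the saturated chain, as the earlier pair spoke only to the halogen on the ring; the position accepts one added methyl without a separable change in the number. No measured evidence bears on this result.

Still open, on these data alone, is whether a longer chain such as butyl would separate from compound 1. As far as these compounds go, an amine or a carboxylic acid on this chain also remains untested here.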